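Sulfamoyl to methyl: compound 1 to compound 3

A few compounds are considered here, and "the series" means these few. Any claim that something is new, unique, unknown or untested is made for them only; others in the source may bear on it.

Measured in an ADME assay for permeability, using PAMPA; a higher number here means that the compound crosses the layer faster, a lower number that the compound crosses the layer more slowly:
- compound 1 `NS(=O)(=O)c1ccc(NC(=O)c2cc(Cl)ccc2O)cc1`: < 1 10^-6 cm/s (a limit of the assay, not a number)
- compound 2 `COc1ccc(Cl)c(NC(=O)c2cc(Cl)ccc2O)c1`: 34 10^-6 cm/s

Compound 1 has no number in this assay, only a limit: the limit of < 1 10^-6 cm/s in this assay, at which 1 of the 2 values shown sits.

Compound 3 `Cc1ccc(NC(=O)c2cc(Cl)ccc2O)cc1` has methyl in place of sulfamoyl on an aromatic carbon, para to a large group: methyl in place of sulfamoyl on an aromatic carbon.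

Among the measured compounds shown here, no measured step bears on this change. For the measured compounds named here, the only guide is compound 2, which also lacks sulfamoyl and gives 34 10^-6 cm/s. A rise beyond the scatter is therefore expected, estimated as an at least 30-fold higher number from compound 1 to compound 3 (1.47 log units; beyond the scatter). Compound 3 is expected at 30 10^-6 cm/s, with an estimated range of 12 10^-6 cm/s to 70 10^-6 cm/s.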

Compound 3, apparent permeability in the ADME assay: 21 10^-6 cm/s
For compound 3 the middle estimate is 1.4-fold (0.15 log units) above the measured one; the range from low to high includes it.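

the ADME assay now has a step at this position, with methyl in place of sulfamoyl on an aromatic carbon: an at least 21-fold higher number from compound 1 to compound 3 (1.32 log units; beyond the scatter). Compound 1 holds a limit there, not a number: the limit of < 1 10^-6 cm/s in the ADME assay, at which 1 of the 3 values shown sits. In a physicochemical assay for solubility (a lower number here means a less soluble compound, a higher number a more soluble compound), compound 1 gives > 48 ug/mL as a limit of the assay, not a number. In the physicochemical assay compound 3 gives < 1 ug/mL and this too is a limit of the assay, not a number. In the physicochemical assay the same change runs the opposite way, with limits of the assay at both ends: the measured solubility of compound 1, > 48 ug/mL, and of compound 3, < 1 ug/mL, an at least 48-fold lower number (1.68 log units; beyond the scatter)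

As far as these compounds go, whether an amine, a carboxylic acid or a longer chain at this position would fall between methyl and sulfamoyl in both read-outs stays open. From the compounds shown here alone, the true size of both steps also stays open.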